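A Smaller Ring Substituent on Compound 2

This account rests on a few compounds, and the source may have more. Where it says the series, first, only, none or still open, it means among the compounds named here.

Compound 1 `Cc1cc(=O)c2c(O)cc(OCc3ccc([N+](=O)[O-])cc3)c([C@H]3CCN(C)C[C@H]3O)c2o1` gives 39% 
Compound 2 `Cc1cc(=O)c2c(O)c(CN3CCC(Cc4ccccc4)CC3)c(O)c([C@H]3CCN(C)C[C@H]3O)c2o1` gives 17% 

In a functional assay on MCF7 cells (Homo sapiens) for inhibition, read by MTT assay, with a stated time of 48 h, tested at 10 uM (on this read-out lower numbers stand for less inhibition of growth and higher numbers for more inhibition of growth at the one concentration tested), compound 2 gives 17% as the lower of the two numbers, and compound 1 at 39% stands above it by more than the usual scatter. These two compounds differ in more than one place, so their gap singles out no one group. Compound 3 `Cc1cc(=O)c2c(O)c(CN3CCCCC3)c(O)c([C@H]3CCN(C)C[C@H]3O)c2o1` keeps everything in compound 2 except one spot: hydrogen in place of benzyl on a saturated ring carbon with hydrogen in place of benzyl on a saturated ring carbon. For the measured compounds named here, no measured pair shows this change alone, so the guide is thin. The expected change a number 5 percentage points higher from compound 2 to compound 3 (within the scatter) is small and upward, and likely stays within the scatter. For compound 3 the estimated value is 22% within an expected range from 6% to 42% for a single measurement.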

Compound 3, percent growth inhibition at one concentration: 15%
Compound 3: middle estimate off by 7 percentage points, on the high side; the measured number falls inside the stated range.
By their numbers in this assay, from the lowest: compounds 3 and 2 (each within the scatter of the next); then compound 1.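

Compound 2 and compound 3 differ in one place, so this pair isolates the swap of benzyl for hydrogen on the saturated ring carbon, three ring bonds from the ring nitrogen. In this assay the step is a number 2 percentage points lower from compound 2 to compound 3 (within the scatter), so at this one concentration the read-out does not separate a ring carbon bearing benzyl from one bearing only hydrogen. No measurement offered here explains this result.

Going by these compounds, whether a group unlike benzyl, such as methyl, a primary amine or a carboxylic acid, on this same ring carbon would give a number outside the scatter remains open. Readings at other concentrations would also be needed to tell whether compound 2 and compound 3 stay this close.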